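A few compounds are considered here, and "the series" means these few. Any claim that something is new, unique, unknown or untested is made for them only; others in the source may bear on it.

The study is about cytotoxicity of two analogues sharing one core, compound 1 `CCOc1ccc(-c2nnc(SCCn3c([N+](=O)[O-])cnc3C)o2)cc1` and compound 2 `Cc1ncc([N+](=O)[O-])n1CCSc1nnc(-c2ccc(F)cc2)o1`. In a functional assay on SGC-7901 cells (Homo sapiens) for cytotoxicity, read by MTT assay, with a stated time of 48 h (on this read-out higher numbers stand for weaker inhibition and lower numbers for stronger inhibition), compound 1 gives 14100 nM, and in this assay compound 2 gives 5300 nM. Among the measured compounds shown here, the only measured step, a 2.7-fold lower number from compound 1 to compound 2 (0.42 log units; beyond the scatter), was brought about by fluoro in place of ethoxy on an aromatic carbon. Among the two numbers available, compound 2 therefore holds the lower one, and it serves as the point of departure for the next compound, compound 3 `Cc1ncc([N+](=O)[O-])n1CCSc1nnc(-c2ccc(N)nc2)o1`. Compound 3 differs from compound 2 in a single place: 6-aminopyridin-3-yl in place of 4-fluorophenyl on an aromatic carbon. For the measured compounds named here, no measured step exchanges a whole aromatic ring in this way; the step from compound 1 to compound 2 only swaps a substituent on the same ring, so its size gives little guidance here. Without a bearing step, the estimate for compound 3 in this assay is set close to compound 2, as 6500 nM, expected to fall between 2000 nM and 22000 nM. The step that this estimate implies, a 1.2-fold higher number from compound 2 to compound 3 (0.09 log units; within the scatter), is expected to lie within the scatter, in no definite direction.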

Compound 3, half-maximal inhibitory concentration: 30900 nM
Beside the measured number, compound 3's estimate is 4.8-fold (0.68 log units) below it; measured number outside the range, above it.
By their numbers in this assay, from the lowest: compound 2; then compound 1; then compound 3.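

In this assay, the position on the five-membered aromatic ring proves sensitive to the identity of the whole aromatic ring and not only to a substituent on it: 6-aminopyridin-3-yl in place of 4-fluorophenyl gives a 5.8-fold higher number from compound 2 to compound 3 (0.77 log units; beyond the scatter), so the change goes with weaker inhibition, whereas fluoro in place of ethoxy gave a 2.7-fold lower number from compound 1 to compound 2 (0.42 log units; beyond the scatter). This change brings in a ring nitrogen and an amino group together, so the pair cannot show which of them carries the step. Nothing available explains the size or direction of this step.

From the compounds shown here alone, it remains open whether a pyridin-3-yl group without the amine or a 4-aminophenyl group would stay close to compound 2 or follow compound 3. Also open, going by these compounds, is how a carboxylic acid or a longer chain on the aromatic ring would behave here.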